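Biaryl acrylic acids: a phenyl step from compound 1

A few compounds are considered here, and "the series" means these few. Any claim that something is new, unique, unknown or untested is made for them only; others in the source may bear on it.

Measured so far in a functional assay on IGROV-1 cells (Homo sapiens) for inhibition; a lower number here means a stronger inhibitor, a higher number a weaker inhibitor:
compound 1, `O=C(O)/C=C/c1ccc(-c2ccc(O)cc2)cc1`, gives 89000 nM
compound 2, `O=C(O)/C=C/c1ccc(-c2ccc(O)c(CC3CCCCCCCCCCC3)c2)cc1`, gives 3570 nM

Compound 1 carries the higher of the two numbers; the gap to compound 2 is far beyond the scatter of this assay. Among the measured compounds shown here, compound 2 differs from compound 1 in more than one respect, so no single-change step between measured compounds is available, and the comparison can only say that compound 2 reaches a much lower number than compound 1.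

The next candidate is compound 3, `O=C(O)/C=C/c1ccc(-c2ccc(O)c(-c3ccccc3)c2)cc1`. Relative to compound 1 the change is phenyl in place of hydrogen on an aromatic carbon. For the measured compounds named here, the only guide is compound 2, where a substituent on the aromatic carbon ortho to the hydroxy group goes together with a far lower number than in compound 1. The phenyl group of compound 3 is a smaller addition than the group of compound 2, so a downward step is expected but of lesser size. The expected step from compound 1 is a 3.6-fold lower number from compound 1 to compound 3 (0.55 log units; beyond the scatter), beyond the scatter. In this assay compound 3 is estimated at 25000 nM, with a range of 8000 nM to 70000 nM.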

Compound 3, half-maximal inhibitory concentration: 19000 nM
Compound 3: middle estimate off by 1.3-fold (0.12 log units), on the high side, and the stated range covers the measured number.
By their numbers in this assay, from the lowest: compound 2; then compound 3; then compound 1.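

In this assay, among the compounds shown here, phenyl in place of hydrogen on the aromatic carbon ortho to a hydroxy group gives a 4.7-fold lower number from compound 1 to compound 3 (0.67 log units; beyond the scatter), which is the first single-change reading for this position: the drop in the number now belongs to one named group rather than to a comparison across several differences. The entering phenyl has 0 hydrogen-bond donors and 0 hydrogen-bond acceptors, so a step of this size at this position needs neither in the added group, while compound 3 at 19000 nM still stands above compound 2 at 3570 nM. Nothing measured bears on why the number falls with this change.

From the compounds shown here alone, whether the aromatic ring matters or any carbon group would do stays open, and a methyl, a cyclohexyl or a short alkyl chain at the same carbon would separate those readings. Also open, going by these compounds, are whether the step survives with the hydroxy group replaced by methoxy, and whether an amine or a carboxylic acid on the added phenyl moves the number further in either direction.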